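Extending the methylamino group of compound 1

A few compounds are considered here, and "the series" means these few. Any claim that something is new, unique, unknown or untested is made for them only; others in the source may bear on it.

In an ADME assay on cells (Homo sapiens) for cytotoxicity, read by polymerase chain reaction, with a stated time of 3 days (a higher number here means that more compound is tolerated, a lower number that less compound is tolerated), compound 1 `CNc1nc(C)c(-c2nc3cnccc3s2)c(N[C@@H]2C[C@H](CO)[C@@H](O)[C@H]2O)n1` gives 14000 nM. It has one measured neighbour, compound 2 `Cc1nc(NC2CC2)nc(N[C@@H]2C[C@H](CO)[C@@H](O)[C@H]2O)c1-c1nc2cnccc2s1`, which gives 25000 nM, and the two numbers lie within the scatter of each other.

Compound 3 `Cc1nc(NCC2CCN(C)CC2)nc(N[C@@H]2C[C@H](CO)[C@@H](O)[C@H]2O)c1-c1nc2cnccc2s1` has not yet been measured. Its difference from compound 1 is 1-methylpiperidin-4-yl in place of hydrogen on a saturated chain carbon bound to a nitrogen on an aromatic ring. Cut one bond further out, the same difference reads methylamino to ((1-methylpiperidin-4-yl)methyl)amino.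

For the measured compounds named here, one measured step bears on this change: a 1.8-fold higher number from compound 1 to compound 2 (0.25 log units; within the scatter), with cyclopropyl in place of methyl on a nitrogen on an aromatic ring. That step alters the substituent on the same nitrogen, but it brings in no six-membered non-aromatic ring with a hetero atom, so it is only a loose guide. With that single small step as the evidence, no change beyond the scatter is expected in this assay, though the range has to stay wide in both directions.

The estimate corresponds to an expected 1.1-fold higher number from compound 1 to compound 3 (0.06 log units; within the scatter). Compound 3 is expected at 16000 nM, with an estimated range of 5000 nM to 45000 nM.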

Compound 3, half-maximal cytotoxic concentration: 25000 nM
Beside the measured number, compound 3's estimate is 1.6-fold (0.19 log units) below it; the measured number falls inside the stated range.
By their numbers in this assay, from the lowest: compounds 1, 2 and 3 (each within the scatter of the next).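

The earlier pair showed only a swap of methyl for cyclopropyl on this nitrogen on an aromatic ring. Compound 3 shows that a much bigger addition, a 1-methylpiperidin-4-yl group of 7 heavy atoms on the saturated chain carbon, also leaves the number in this assay within the scatter (a 1.8-fold higher number from compound 1 to compound 3 (0.25 log units; within the scatter)). Set against the cyclopropyl group of compound 2, the (1-methylpiperidin-4-yl)methyl group gives the same reading (no change at the digits printed from compound 2 to compound 3 (within the scatter)), so in this assay all three substituents on this nitrogen lie within the scatter of one another, and nothing available explains that insensitivity.

The compounds shown leave open whether this holds once the ring nitrogen of the piperidine is gone, as in a cyclohexylmethyl group, or once a carboxylic acid or a longer chain stands on the same nitrogen. They also leave open whether the same tolerance would appear with any other part of the shared core changed, since all three compounds differ at this one nitrogen only.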